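Nitro addition to the methoxy quinolinone benzimidazole

The source may report more compounds than this note shows. Statements on the series, on what has been measured and on what is new or still open speak of the compounds shown alone.

Compound 1 `Cc1ccc2[nH]c(=O)c(-c3nc4cc([N+](=O)[O-])ccc4[nH]3)cc2c1`; compound 2 `COc1ccc2[nH]c(=O)c(-c3nc4ccccc4[nH]3)cc2c1`; compound 3 `COc1ccc2[nH]c(=O)c(-c3nc4cc([N+](=O)[O-])ccc4[nH]3)cc2c1`, not yet measured.

In a functional assay on NCI-H460 cells (Homo sapiens) for cytotoxicity, read by MTT assay, with a stated time of 48 h (a higher number here means a weaker inhibitor, a lower number a stronger inhibitor), compound 1 gives > 100000 nM, a limit of the assay and not a number. In this assay compound 2 also returns only a limit, > 100000 nM. Compound 2 thus stands at the limit of > 100000 nM in this assay, at which 2 of the 2 values shown sit. Compound 3 differs from compound 2 by nitro in place of hydrogen on an aromatic carbon. For the measured compounds named here, no measured step covers this change; the expected step of a number no higher from compound 2 to compound 3 (the limit leaves the size open) is none beyond the scatter, since both neighbours sit at the limit. Compound 3 is estimated at 100000 nM, range 30000 nM to 300000 nM.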

Compound 3, half-maximal inhibitory concentration: > 100000 nM
Compound 3: no number, only a limit; the forecaster's own chance of this, stated with the estimate: 80%; the middle value sits exactly at the limit.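

No step to compound 3 can be read from compound 1 or compound 2, as all three compounds return only a limit of the assay in this assay: the limit of > 100000 nM in this assay, at which 3 of the 3 values shown sit.

The compounds shown leave open how these three rank and whether either nitro or methoxy in place of methyl changes the read-out.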